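Azide tail shortening on the amide-linked triazole analogue

This account rests on a few compounds, and the source may have more. Where it says the series, first, only, none or still open, it means among the compounds named here.

Compound 1 `C#CCNC(=O)CN(Cc1ccccc1)Cc1c(-c2ccc(NC(=O)NCC)cc2)nc2n(Cc3c(F)cccc3F)cc(C(=O)OCC)c(=O)n12` and compound 2 `CCNC(=O)Nc1ccc(-c2nc3n(Cc4c(F)cccc4F)cc(C(=O)OCC)c(=O)n3c2CN(CC(=O)NCc2cn(CCOCCN=[N+]=[N-])nn2)Cc2ccccc2)cc1` both carry the ester on the shared core; in a functional assay on CHO cells for antagonist activity at Gonadotropin-releasing hormone receptor (Homo sapiens), read by a luciferase reporter, with a stated time of 30 min (a lower number here means a stronger inhibitor, a higher number a weaker inhibitor), compound 1 gives 1000 nM, and in this assay compound 2 gives 525 nM, two values that sit within the usual scatter of each other. Compound 3 `CCNC(=O)Nc1ccc(-c2nc3n(Cc4c(F)cccc4F)cc(C(=O)NCc4cn(CCOCCN=[N+]=[N-])nn4)c(=O)n3c2CN(C)Cc2ccccc2)cc1` moves the triazole-bearing chain onto the amide and carries a methyl on the benzylic amine. For compound 3 only a limit of the assay is known: in this assay compound 3 gives < 10000 nM, and this is a limit rather than a number (the limit of < 10000 nM in this assay, at which 1 of the 3 values shown sits). Compound 4 `CCNC(=O)Nc1ccc(-c2nc3n(Cc4c(F)cccc4F)cc(C(=O)NCc4cn(CCN=[N+]=[N-])nn4)c(=O)n3c2CN(C)Cc2ccccc2)cc1` follows from compound 3 by the change (azido in place of 2-azidoethoxy on a saturated chain carbon, two bonds along the chain from an aromatic nitrogen). The difference lies in the chain beyond the triazole and leaves the core and the amide untouched, so no step beyond the scatter is expected from compound 3 to compound 4, and the expected shift is a step that the limit leaves unreadable from compound 3 to compound 4. Where compound 3 only reaches a limit, a plain number for compound 4 is uncertain; the estimate for compound 4 is 3000 nM, with a range from 600 nM to 10000 nM.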

Compound 4, half-maximal inhibitory concentration: < 10000 nM
Compound 4 gave a limit, no number; the forecaster's own chance of this, stated with the estimate: 50%; the middle value is on the limit's open side.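

Compound 4 in this assay gives < 10000 nM as a limit and not a number. Compound 3 also stands at a limit, so no step can be read between compound 3 and compound 4: the limit of < 10000 nM in this assay, at which 2 of the 4 values shown sit. As far as these compounds go, whether azido and 2-azidoethoxy differ at all on this chain remains open, as does where the plain values of compound 3 and compound 4 lie.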